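Moving the Carboxy Group on the Pyrazole Ring

A few compounds are considered here, and "the series" means these few. Any claim that something is new, unique, unknown or untested is made for them only; others in the source may bear on it.

Compound 1, `O=C(O)c1cncn1Cc1cc(Br)ccc1OCc1ccccc1`, in a functional assay on CHO-K1 cells for antagonist activity at prostaglandin E2 receptor EP1 subtype (Homo sapiens), read by FLIPR (on this read-out lower numbers stand for stronger inhibition and higher numbers for weaker inhibition), gives < 2000 nM, a limit of the assay.
Compound 2, `O=C(O)c1ccnn1Cc1cc(Br)ccc1OCc1ccccc1`, in this assay gives < 2000 nM, likewise a limit.

Compound 2 therefore stands at the limit where both measured values sit (the limit of < 2000 nM in this assay, at which 2 of the 2 values shown sit). The step that the two limits leave unreadable from compound 1 to compound 2 cannot be read from two limits. Compound 3, `O=C(O)c1cnn(Cc2cc(Br)ccc2OCc2ccccc2)c1`, differs from compound 2 by 4-carboxy-1H-pyrazol-1-yl in place of 5-carboxy-1H-pyrazol-1-yl on a saturated chain carbon bound to an aromatic carbon. Among the compounds with values here, no measured step covers this change, and the only known step is unreadable, so no change beyond the usual scatter is expected. The expected step is a step that the limit leaves unreadable from compound 2 to compound 3. Compound 3 is estimated at 800 nM, within a range from 80 nM to 8000 nM.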

Compound 3, inhibition constant: < 2000 nM
Compound 3: a limit, no number; the forecaster's own chance of this, stated with the estimate: 60%; the middle value is on the limit's open side.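

Compound 3 also gives only a limit, so no step among compound 1, compound 2 and compound 3 can be read: the limit of < 2000 nM in this assay, at which 3 of the 3 values shown sit.

Going by these compounds, whether the place of the carboxy group on the pyrazole changes the true strength in this assay stays open.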